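The source may report more compounds than this note shows. Statements on the series, on what has been measured and on what is new or still open speak of the compounds shown alone.

Measured so far in an assay on isolated protein for inhibition of serine/threonine-protein kinase PLK2 (Homo sapiens), read by TR-FRET, with a stated time of 60 min; a higher number here means a weaker inhibitor, a lower number a stronger inhibitor:
- compound 1 `CC[C@@H]1C(=O)N(C)c2cnc(-n3ccnc3-c3ccccc3)nc2N1C1CCCC1`: 5 nM
- compound 3 `CCC1C(=O)N(C)c2cnc(-n3ccnc3-c3ccccc3)nc2N1c1ccccc1`: 17 nM
- compound 2 `CC(C)N1c2nc(-n3ccnc3-c3ccc(F)cc3)ncc2N(C)C(=O)C1(C)C`: 2710 nM

Compound 1 stands at the lowest number of the three. Compound 3 lies beyond the scatter above it, and compound 2 lies far beyond it. Among the compounds with values here, no pair among the measured compounds differs in one place only, so none of these gaps can be tied to a single structural change; compound 3 differs from compound 1 at the nitrogen substituent and in the stereochemistry at the ethyl-bearing carbon, and compound 2 differs at several places at once.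

Compound 4 `CC[C@@H]1C(=O)N(C)c2cnc(-n3ccnc3-c3ccccc3)nc2N1CCC(F)(F)F` takes the step from compound 1 described by 3,3,3-trifluoropropyl in place of cyclopentyl on a nitrogen on an aromatic ring in a ring. Within the data shown here, no measured step isolates this change, so the expectation rests on the series as a whole: the substituent on this nitrogen is the one place where compound 1 and compound 3 differ most plainly, and that gap is modest. The step of a 3.0-fold higher number from compound 1 to compound 4 (0.48 log units; beyond the scatter) is therefore expected to be a small move toward a higher number, close to the edge of the scatter rather than a collapse of the kind seen with compound 2. Compound 4 is expected to give 15 nM in this assay, with a plausible range from 4 nM to 60 nM.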

Compound 4, half-maximal inhibitory concentration: 9 nM
Compound 4: the middle estimate sits 1.7-fold (0.22 log units) above what was measured; low and high end bracket the measured number.
By their numbers in this assay, from the lowest: compounds 1, 4 and 3 (each within the scatter of the next, the first and the last beyond it); then compound 2.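

In this assay, within the data shown here, the step to 3,3,3-trifluoropropyl in place of cyclopentyl on this nitrogen is a 1.8-fold higher number from compound 1 to compound 4 (0.26 log units; within the scatter), the first reading that isolates a change at this position, and it lies within the scatter. For this pair, the five-membered non-aromatic ring of carbon only is therefore not needed to keep a value in the range of compound 1, since a substituent with no ring cannot be told apart from it in this assay. No measurement on hand bears on why these two groups read alike.

The compounds shown leave open whether the fluorine atoms have any part in this result, a question that a plain propyl chain at the same nitrogen would address by comparison with compound 4. They also leave open how far this position accepts other groups, such as a longer chain, a chain ending in an amine or a carboxylic acid, or a six-membered ring of carbon only in place of cyclopentyl.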